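The source may report more compounds than this note shows. Statements on the series, on what has been measured and on what is new or still open speak of the compounds shown alone.

Working notes on the series. All three measured compounds share one core and differ only in the side chain carried on the ring oxygen. In a functional assay on SK-BR-3 cells (Homo sapiens) for antiproliferative activity (on this read-out higher numbers stand for weaker inhibition and lower numbers for stronger inhibition), compound 2 `CC(C)=CCc1cc(C(=O)Nc2cc3ccc(OCCCNCC(C)C)c(C)c3oc2=O)ccc1O` gives 1030 nM. On the numbers it has the second highest of the three, though every step among them lies within the scatter. Compound 1 `CC(C)=CCc1cc(C(=O)Nc2cc3ccc(OCC4CCN(C)C4)c(C)c3oc2=O)ccc1O` gives 920 nM in this assay, and compound 3 `CC(C)=CCc1cc(C(=O)Nc2cc3ccc(OCCCN(C(C)C)C(C)C)c(C)c3oc2=O)ccc1O` gives 1600 nM. The steps are a 1.1-fold higher number from compound 1 to compound 2 (0.05 log units; within the scatter), a 1.7-fold higher number from compound 1 to compound 3 (0.24 log units; within the scatter) and a 1.6-fold higher number from compound 2 to compound 3 (0.19 log units; within the scatter).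

Compound 4 `CC(C)=CCc1cc(C(=O)Nc2cc3ccc(OCCCN[C@H](C)c4ccccc4)c(C)c3oc2=O)ccc1O` is not yet measured. It differs from compound 2 in one place: 1-phenylethyl in place of isobutyl on an amine nitrogen. Going by the values given here, the one measured step at the same amine nitrogen, a 1.6-fold higher number from compound 2 to compound 3 (0.19 log units; within the scatter), stayed within the scatter, and the two replacements of the whole chain end, a 1.1-fold higher number from compound 1 to compound 2 (0.05 log units; within the scatter) and a 1.7-fold higher number from compound 1 to compound 3 (0.24 log units; within the scatter), did no more. Among the compounds with values here, no measured step involves an aromatic ring entering on the amine nitrogen. A step no larger than the scatter, without a clear direction, is therefore expected, a 1.1-fold higher number from compound 2 to compound 4 (0.03 log units; within the scatter). Compound 4 is estimated at 1100 nM, with a range from 450 nM to 2700 nM.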

Compound 4, half-maximal inhibitory concentration: 1000 nM
The estimate for compound 4 lay 1.1-fold (0.04 log units) above the measured number, and the stated range covers the measured number.
By their numbers in this assay, from the lowest: compounds 1, 4, 2 and 3 (each within the scatter of the next).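

At the amine nitrogen, 1-phenylethyl brings in a six-membered aromatic ring of carbon only and a defined stereocentre, a kind of change the other compounds do not cover, yet in this assay it gives a 1.0-fold lower number from compound 2 to compound 4 (0.01 log units; within the scatter). Against the other two chain ends the picture is the same, with a 1.6-fold lower number from compound 3 to compound 4 (0.20 log units; within the scatter) and a 1.1-fold higher number from compound 1 to compound 4 (0.04 log units; within the scatter), so this side chain position has so far produced no step beyond the scatter and the four compounds cannot be ranked. No measured evidence bears on this result.

The compounds shown leave open what the mirror-image 1-phenylethyl group, or a benzyl or fluorophenyl group on this nitrogen, would give. Also open, as far as these compounds go, is whether a longer chain between the ring oxygen and the amine nitrogen would move the number beyond the scatter.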